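This account rests on a few compounds, and the source may have more. Where it says the series, first, only, none or still open, it means among the compounds named here.

Of the compounds shown here, two have been measured in a functional assay on L1210 cells (Mus musculus) for inhibition; on this read-out lower numbers stand for an effect already at smaller amounts and higher numbers for an effect only at larger amounts of compound. Compound 1 `C=CCSc1nc(N)nc2c1ncn2[C@H]1C[C@H](O)[C@@H](CO)O1` gives 3 uM in this assay, and compound 2 `Cc1cccc(CSc2nc(N)nc3c2ncn3[C@@H]2C[C@H](O)[C@@H](CO)O2)n1` gives 72 uM. Compound 2 therefore stands at the higher of the two numbers, a gap beyond the usual scatter, so compound 2 needs clearly more material than compound 1 to reach the same effect.

Compound 3 `Cc1cccc(CSc2nc(N)nc3c2ncn3[C@H]2C[C@H](O)[C@@H](CO)O2)n1` is the unmeasured partner of compound 2. The change is the two compounds have the same atoms and bonds and differ only in configuration as drawn: 1 of 3 stereo elements differ; a stereocentre at a saturated ring carbon is drawn S in compound 2 and R in compound 3. At that ring carbon, compound 3 is drawn the same way as compound 1, while compound 2 is drawn the other way. Among the compounds with values here, no measured pair differs only in this stereocentre, so the size of the step is uncertain; the expectation is a moderate move toward a lower number in this assay, though a move within the scatter cannot be excluded. The expected step is a 4.8-fold lower number from compound 2 to compound 3 (0.68 log units; beyond the scatter). For compound 3 the estimate is 15 uM, within a range from 3 uM to 70 uM.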

Compound 3, concentration for half-maximal effect: 31 uM
For compound 3 the middle estimate is 2.1-fold (0.32 log units) below the measured one; low and high end bracket the measured number.
By their numbers in this assay, from the lowest: compound 1; then compound 3; then compound 2.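

Changing only how one saturated ring carbon is drawn, from S to R, gives a 2.3-fold lower number from compound 2 to compound 3 (0.37 log units; beyond the scatter) in this assay. The step can be read as an effect of configuration alone: the fact that compounds 2 and 3 differ only in the configuration as drawn. With that ring carbon now drawn alike in both compounds, the side chain can be compared on its own: 6-methylpyridin-2-yl in place of vinyl on a saturated chain carbon bound to a sulfur gives a 10-fold higher number from compound 1 to compound 3 (1.01 log units; beyond the scatter), a large step.

On these data alone, it remains open whether the same stereo change would have a similar effect on a compound carrying the vinyl group, since the step is known only with 6-methylpyridin-2-yl. Also open, as far as these compounds go, is how the number would respond to a plain benzyl group or a longer alkyl chain in the same place.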